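Compound 3: trifluoromethyl in place of phenyl

This account rests on a few compounds, and the source may have more. Where it says the series, first, only, none or still open, it means among the compounds named here.

Measured in a functional assay on UO-31 cells (Homo sapiens) for inhibition, read by sulforhodamine B assay, with a stated time of 48 h, tested at 10 uM; on this read-out higher numbers stand for more inhibition of growth at the one concentration tested and lower numbers for less inhibition of growth:
- compound 1 `CC(=O)c1cccc(Nc2ccnc(SCC(=O)c3ccc(-c4ccccc4)cc3)n2)c1`: 40%
- compound 2 `CC(=O)c1ccc(Nc2ccnc(SCC(=O)c3ccc(-c4ccccc4)cc3)n2)cc1`: 27%

Of these two, compound 1 stands highest, at 40%. Going by the values given here, the only measured step is a number 13 percentage points lower from compound 1 to compound 2 (beyond the scatter), with 4-acetylphenyl in place of 3-acetylphenyl.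

Compound 3 `CC(=O)c1cccc(Nc2ccnc(SCC(=O)c3ccc(C(F)(F)F)cc3)n2)c1` keeps the 3-acetylphenyl group of compound 1 and differs from it at one place: trifluoromethyl in place of phenyl on an aromatic carbon. The change sits on an aromatic carbon, para to a large group. Among the compounds with values here, no measured step covers this change, and the data hold no other compound with phenyl replaced. The step of a number 13 percentage points lower from compound 1 to compound 2 (beyond the scatter) therefore bears only indirectly, as a guide to how far one change can move the number in this series. A step of similar modest size in this assay is expected, with the direction only weakly downward, because compound 1 is the higher of the two measured compounds at 40%. The expected change is a number 12 percentage points lower from compound 1 to compound 3 (beyond the scatter), and a result within the scatter would not be surprising.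

For compound 3 the estimate is 28%, with an expected range of 10% to 48%.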

Compound 3, percent growth inhibition at one concentration: 57%
Beside the measured number, compound 3's estimate is 29 percentage points below it; measured number above the stated range.
By their numbers in this assay, from the lowest: compound 2; then compound 1; then compound 3.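

In this assay the aromatic carbon para to a large group proves to be a place where a change moves the number: trifluoromethyl in place of phenyl gives a number 17 percentage points higher from compound 1 to compound 3 (beyond the scatter). Going by these compounds alone, the phenyl, with its six-membered aromatic ring of carbon only, is therefore not required here for growth inhibition at the one concentration tested, and a group with no ring does better on this read-out; the only change measured before this lay in the acetylphenyl group on the nitrogen. Nothing on hand accounts for the rise, so it stands as an observation only.

Open, going by these compounds, is what other groups at this aromatic carbon would do, such as a single fluorine, a methyl, an amine or a carboxylic acid, and whether the number follows any order across them. Also open, on these data alone, is whether 4-acetylphenyl in place of 3-acetylphenyl carries the same cost with trifluoromethyl at this place as with phenyl, where it gives a number 13 percentage points lower from compound 1 to compound 2 (beyond the scatter).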